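The source may report more compounds than this note shows. Statements on the series, on what has been measured and on what is new or still open speak of the compounds shown alone.

Working notes on the series.

Of the compounds shown here, two have numbers so far. Compound 1 `NC(=S)N/N=C1/C(=O)N(CN2CCN(c3ccnc4cc(Cl)ccc34)CC2)c2ccccc21` is the parent with an unsubstituted core; in a functional assay on MDA-MB-468 cells (Homo sapiens) for cytotoxicity, read by sulforhodamine B assay, with a stated time of 48 h (on this read-out higher numbers stand for weaker inhibition of growth and lower numbers for stronger inhibition of growth), compound 1 gives 20600 nM. Compound 2 `NC(=S)N/N=C1/C(=O)N(CN2CCN(c3ccnc4cc(C(F)(F)F)ccc34)CC2)c2cc(Cl)ccc21` carries a trifluoromethyl on the fused bicyclic amine and a chloro on the core; in this assay compound 2 gives 11000 nM. Going by the values given here, the gap between the two numbers is within the scatter of repeated measurements, so the two compounds cannot be told apart on this read-out, and no single-change step between measured compounds is available to calibrate the effect of any one substituent.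

The next compound, compound 3 `NC(=S)N/N=C1/C(=O)N(CN2CCN(c3ccnc4cc(C(F)(F)F)ccc34)CC2)c2ccccc21`, keeps the trifluoromethyl of compound 2 and differs from it only in one place: hydrogen in place of chloro on an aromatic carbon. With no measured step of this kind in hand, the expectation rests on the two numbers alone, and both point to a flat landscape: the step from compound 2 to compound 3 is expected to be small, a 1.4-fold higher number from compound 2 to compound 3 (0.13 log units; within the scatter), and not beyond the scatter in either direction. On that basis compound 3 is estimated at 15000 nM in this assay, with a range from 6000 nM to 40000 nM.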

Compound 3, concentration for 50% growth inhibition: 10300 nM
Beside the measured number, compound 3's estimate is 1.5-fold (0.16 log units) above it; the measured number falls inside the stated range.
By their numbers in this assay, from the lowest: compounds 3, 2 and 1 (each within the scatter of the next).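

In this assay, the series now has its first single-place reading at this position: hydrogen in place of chloro on an aromatic carbon, meta to a fused ring and para to a fused ring, gives a 1.1-fold lower number from compound 2 to compound 3 (0.03 log units; within the scatter). At the other varied place, trifluoromethyl in place of chloro on an aromatic carbon gives a 2.0-fold lower number from compound 1 to compound 3 (0.30 log units; within the scatter). Neither exchange separates its pair of compounds on this read-out, so the flat picture suggested earlier by two compounds differing in two places now rests on two separate single-place comparisons, and nothing available explains the size of either step.

The compounds shown cover only chloro and hydrogen at this position, so it stays open whether an amine or a carboxylic acid on the same aromatic carbon would give a step beyond the scatter. With trifluoromethyl and chloro as the only groups shown at the other place, it also stays open whether a methoxy group or a nitrile there would separate from compound 3.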